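The compounds below may be only part of what the source reports. "The series", "measured", "known", "first", "only" and "open" are said of these compounds alone.

Compound 1 `Cc1c(Cc2ccc(OC(F)(F)F)cc2)c(=O)oc2cc(OCC(O)CN3CCC(C(N)=O)CC3)ccc12` gives 68200 nM in an ADME assay on A549 cells (Homo sapiens) for cytotoxicity, read by CellTiter-Glo; on this read-out higher numbers stand for lower toxicity in this test and lower numbers for higher toxicity in this test.
Compound 2 `Cc1c(Cc2ccc(-c3ccc(C(F)(F)F)cc3)cc2)c(=O)oc2cc(OCC(O)CN3CCC(C(N)=O)CC3)ccc12` gives > 100000 nM in this assay, which is a limit of the assay rather than a number.

In this assay compound 2 stands only at a limit, namely (the limit of > 100000 nM in this assay, at which 1 of the 2 values shown sits), and so the step of an at least 1.4-fold higher number from compound 1 to compound 2 (0.16 log units; that floor lies within the scatter) has a floor that lies within the scatter because compound 2 sits at the limit of > 100000 nM in this assay, at which 1 of the 2 values shown sits. Compound 3 `Cc1c(Cc2ccc(-c3ccc(C=O)c(F)c3)cc2)c(=O)oc2cc(OCC(O)CN3CCC(C(N)=O)CC3)ccc12` is not yet measured in this assay. Its change from compound 2 is 3-fluoro-4-formylphenyl in place of 4-(trifluoromethyl)phenyl on an aromatic carbon. Going by the values given here, the only measured step that bears on this part of the structure is the one from compound 1 to compound 2, and it showed nothing beyond the scatter, so no step beyond the scatter is expected in this assay when going from compound 2 to compound 3. Compound 3 is therefore estimated to give 90000 nM in this assay, with a range from 35000 nM to 250000 nM, which means an expected step of an at least 1.1-fold lower number from compound 2 to compound 3 (0.04 log units; that floor lies within the scatter).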

Compound 3, half-maximal cytotoxic concentration: 62400 nM
Compound 3: the middle estimate sits 1.4-fold (0.16 log units) above what was measured; the measured number falls inside the stated range.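

In this assay, going by these compounds alone, the change at this position gives an at least 1.6-fold lower number from compound 2 to compound 3 (0.20 log units; that floor lies within the scatter), so swapping one substituted phenyl for another still shows no step that can be read as beyond the scatter. Compound 2 stands only at a limit of the assay, which leaves the true size of that step unread: the limit of > 100000 nM in this assay, at which 1 of the 3 values shown sits. The comparison with two actual numbers on both sides gives a 1.1-fold lower number from compound 1 to compound 3 (0.04 log units; within the scatter), which places the 3-fluoro-4-formylphenyl group and the trifluoromethoxy group within the scatter of each other at this position.

The compounds shown leave open whether any group at this position can move the read-out beyond the scatter. On these data alone, it also remains open what an amine, a carboxylic acid or a nitrile would do in place of the formyl group on this ring.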